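The source may report more compounds than this note shows. Statements on the series, on what has been measured and on what is new or still open speak of the compounds shown alone.

Measured compounds: compound 1 `CCCCCCCCCCCCc1ccccc1C(SCCC(=O)O)SCCC(=O)O` gives 445 nM in an assay on membranes from lung (Cavia porcellus) for binding affinity to cysteinyl leukotriene receptor (Homo sapiens); a lower number here means a stronger inhibitor, a higher number a weaker inhibitor; compound 2 `CCCCCCCCCCCOc1ccc(O)cc1C(SCCC(=O)O)SCCC(=O)O` gives 156 nM in this assay.

Compound 2 stands lowest of the two numbers; compound 1 is the nearest, with a higher number, and that gap lies beyond the scatter. Among the compounds with values here, no pair differing in one place is known, so no measured step guides the next move. Compound 3 `CCCCCCCCCCCOc1ccc(Br)cc1C(SCCC(=O)O)SCCC(=O)O` differs from compound 2 by bromo in place of hydroxy on an aromatic carbon. Without a comparable step, a change of modest size is expected, its direction open, most likely within or just beyond the scatter. Compound 3 is therefore expected to give 220 nM in this assay, within 60 nM to 800 nM, an estimated step of a 1.4-fold higher number from compound 2 to compound 3 (0.15 log units; within the scatter).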

Compound 3, inhibition constant: 624 nM
The estimate for compound 3 lay 2.8-fold (0.45 log units) below the measured number; measured number inside the range.
By their numbers in this assay, from the lowest: compound 2; then compounds 1 and 3 (each within the scatter of the next).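

At this aromatic carbon, meta to a large group and para to a large group, bromo in place of hydroxy gives a 4.0-fold higher number from compound 2 to compound 3 (0.60 log units; beyond the scatter) in this assay. This first measured step at the position shows that the change matters here: the number for hydroxy, with its hydrogen-bond donor and acceptor, lies lower than that for bromo, which has neither. Within the data shown here, nothing measured so far accounts for the step. From the compounds shown here alone, whether a methoxy group, a chlorine or an amine on this carbon would stand nearer compound 2 or compound 3 remains open.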